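Ester to Acid on a Core Where Nothing Yet Reads

A few compounds are considered here, and "the series" means these few. Any claim that something is new, unique, unknown or untested is made for them only; others in the source may bear on it.

Compound 1, `CCOC(=O)C1=Cc2ccccc2OC1(OCc1cc(-c2ccc(F)cc2F)no1)C(F)(F)F`, in a functional assay on HeLa cells (Homo sapiens) for inhibition, read by MTT assay, with a stated time of 24 h (a higher number here means a weaker inhibitor, a lower number a stronger inhibitor), gives > 150000 nM, which is a limit of the assay and not a number.
Compound 2, `CCOC(=O)C1=Cc2ccccc2OC1(OCc1cc(-c2ccc(C)cc2)no1)C(F)(F)F`, in this assay gives > 150000 nM, again a limit of the assay.
Compound 3, `CCOC(=O)C1=Cc2ccccc2OC1(OCc1cc(-c2ccc3ccccc3c2)no1)C(F)(F)F`, in this assay gives > 150000 nM, again a limit of the assay.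

Compound 2 therefore stands at the edge of what this assay can report: its value is a limit, and the other two values are limits as well. Compound 4, `Cc1ccc(-c2cc(COC3(C(F)(F)F)Oc4ccccc4C=C3C(=O)O)on2)cc1`, differs from compound 2 in one place: hydrogen in place of ethyl on an oxygen next to a carbonyl group. The three measured steps, a step that the two limits leave unreadable from compound 1 to compound 2, a step that the two limits leave unreadable from compound 1 to compound 3 and a step that the two limits leave unreadable from compound 2 to compound 3, each exchange one aromatic group for another and leave the ethoxycarbonyl untouched. None of them can be sized, since with the limit of > 150000 nM in this assay, at which 3 of the 3 values shown sit, there is no number on either side to compare. For the measured compounds named here, no measured step thus bears on the change from ethoxycarbonyl to carboxy, and the only guide is that every compound of this core so far sits at the limit. The expectation for compound 4 is a step that the limit leaves unreadable from compound 2 to compound 4, that is, nothing beyond the scatter. Compound 4 is estimated at 200000 nM, in a range from 50000 nM to 1000000 nM, most likely reported again only as a limit.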

Compound 4, half-maximal inhibitory concentration: 33400 nM
The estimate for compound 4 lay 6.0-fold (0.78 log units) above the measured number; measured number outside the range, below it.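

Replacing ethoxycarbonyl with carboxy gives an at least 4.4-fold lower number from compound 2 to compound 4 (0.65 log units; beyond the scatter). For the compounds shown here, this is the first change on the shared core that can be sized in this assay, whereas the exchanges of one aromatic group for another among compound 1, compound 2 and compound 3 cannot be read. The true step may be larger, because compound 2 stands at a limit and not at a number: the limit of > 150000 nM in this assay, at which 3 of the 4 values shown sit.

One pair cannot show whether the shift depends on the carboxy group itself or simply on losing the ethyl, and a methyl ester or a primary amide at this place would help separate the two. Also open, going by these compounds, is whether the 2,4-difluorophenyl and naphthalen-2-yl groups of compound 1 and compound 3 would give readable differences on the carboxy form.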